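A few compounds are considered here, and "the series" means these few. Any claim that something is new, unique, unknown or untested is made for them only; others in the source may bear on it.

Measured in an assay on HL-60 cells for agonist activity at vitamin D3 receptor (Homo sapiens), read by microscopy, with a stated time of 96 h; a higher number here means that more compound is needed for the effect, a lower number that less compound is needed:
compound 1 `CC[C@@H](C)[C@H](NC(=O)c1ccc(C(CC)(CC)c2ccc(OCC(=O)C(C)(C)C)c(C)c2)n1CC)C(=O)OC`: 590 nM
compound 2 `CCN(CC)CCNC(=O)c1ccc(C(CC)(CC)c2ccc(OCC(=O)C(C)(C)C)c(C)c2)n1CC`: 91 nM
compound 3 `CCN(CC)CCCNC(=O)c1ccc(C(CC)(CC)c2ccc(OCC(=O)C(C)(C)C)c(C)c2)n1CC`: 22 nM

Compound 1 gives the highest number of the three in this assay. Its nearest neighbour is compound 2, with a 6.5-fold lower number from compound 1 to compound 2 (0.81 log units; beyond the scatter), and the furthest is compound 3, with a 27-fold lower number from compound 1 to compound 3 (1.43 log units; beyond the scatter). Between the other two there is a 4.1-fold lower number from compound 2 to compound 3 (0.62 log units; beyond the scatter). All three measured steps change only the group on the amide-type nitrogen. Compound 4 `CC[C@@H](C)[C@H](NC(=O)c1ccc(C(CC)(CC)c2ccc(OCC(O)C(C)(C)C)c(C)c2)n1CC)C(=O)OC` differs from compound 1 in another part of the molecule: 1-hydroxy-2,2-dimethylpropyl in place of (tert-butyl)carbonyl on a saturated chain carbon bound to an oxygen on an aromatic ring. For the measured compounds named here, no measured step touches this region, so the three steps give no direct guide to the size or direction of the change. With nothing measured that bears on it, the expectation for compound 4 rests on compound 1 at 590 nM and has to allow a wide range. Compound 4 is therefore estimated at 450 nM in this assay, with a range from 100 nM to 2000 nM. That estimate means a 1.3-fold lower number from compound 1 to compound 4 (0.12 log units; within the scatter), a step expected to stay close to the scatter.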

Compound 4, half-maximal effective concentration: 26 nM
Compound 4: middle estimate off by 17-fold (1.24 log units), on the high side; the measured number lies below the stated range.
By their numbers in this assay, from the lowest: compounds 3 and 4 (each within the scatter of the next); then compound 2; then compound 1.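

In this assay, the change at the saturated chain carbon bound to an oxygen on an aromatic ring gives a 23-fold lower number from compound 1 to compound 4 (1.36 log units; beyond the scatter), which shows that this region, untouched by the amide-nitrogen steps, also affects the number. The change from (tert-butyl)carbonyl to 1-hydroxy-2,2-dimethylpropyl leaves the heavy-atom count the same, removes the double bond and adds a hydrogen-bond donor, yet its step is of similar size to a 27-fold lower number from compound 1 to compound 3 (1.43 log units; beyond the scatter), the largest step among the amide-nitrogen changes. No measurement at hand accounts for this change in the number.

On these data alone, it remains open whether the same change would shift the number similarly in the amides compound 2 and compound 3. Also open, as far as these compounds go, is how a methoxy group or an amine would compare with the hydroxyl group at this position.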